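The source may report more compounds than this note shows. Statements on the series, on what has been measured and on what is new or still open speak of the compounds shown alone.

In an ADME assay on microsomes from liver (Mus musculus) for metabolic stability, read by LC-MS, using NADPH, with a stated time of 30 min, tested at 0.1 uM, in the presence of a further agent that is not named here (on this read-out higher numbers stand for a more stable compound and lower numbers for a less stable compound), compound 1 (`NC(=O)c1ccc(-c2cnc(N)c(-c3ccc(C(F)(F)F)cc3)n2)cc1`) gives > 90% as a limit and not a number. Compound 2 (`Nc1ncc(-c2ccc(C(=O)N3CCC(O)C3)cc2)nc1-c1ccc(C(F)(F)F)cc1`) gives > 90% as a limit too, so it stands at the limit of > 90% in this assay, at which 2 of the 2 values shown sit, with no number of its own. For the measured compounds named here, the only measured step is a step that the two limits leave unreadable from compound 1 to compound 2 and offers no size to carry over. Compound 3 (`Nc1ncc(-c2ccc(C(=O)N3CC[C@@H](O)C3)cc2)nc1-c1ccc(C(F)(F)F)cc1`) has the same atoms and bonds as compound 2: the two compounds have the same atoms and bonds; at least one stereo element is drawn with a configuration in one of them and without one in the other: 1 of 1 stereo elements differ; a stereocentre at a saturated ring carbon is drawn without a configuration in compound 2 and R in compound 3. A change beyond the usual scatter is therefore not expected, and the expected step is a step that the limit leaves unreadable from compound 2 to compound 3 in size. Compound 3 is estimated at 95% within a range from 88% to 100% as expected bounds.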

Compound 3, percent of the compound remaining: > 90%
Compound 3: no number, only a limit (the forecaster's own chance of this, stated with the estimate: 85%); the middle value does not contradict the limit.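

For the compounds shown here, compound 3 gives only a limit and not a number, as do compound 1 and compound 2, so no step among them can be read. In this assay the compounds shown leave open how far each one lies past its limit, and whether the configuration drawn in compound 3 makes any difference.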